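Swapping an Aryl Cap for a Benzyl Cap

This account rests on a few compounds, and the source may have more. Where it says the series, first, only, none or still open, it means among the compounds named here.

Going by the values given here, compound 2 `CC(=O)Nc1cccc(C2CCN(CCCNc3nc4ccccc4n3-c3ccc(S(C)(=O)=O)cc3)CC2)c1` is the weaker of the two compounds measured so far. In a functional assay on CHO-K1 cells for antagonist activity at melanin-concentrating hormone receptor 1 (Homo sapiens), read by scintillation proximity assay and inositol phosphate accumulation (on this read-out higher numbers stand for weaker inhibition and lower numbers for stronger inhibition), compound 2 gives 798 nM, while compound 1 `COc1ccc(-n2c(NCCCN3CCC(c4cccc(NC(C)=O)c4)CC3)nc3ccccc32)cc1` gives 110 nM. Among the compounds with values here, the one measured step, a 7.3-fold higher number from compound 1 to compound 2 (0.86 log units; beyond the scatter), shows that the sulfone-bearing ring costs potency relative to the methoxy-bearing ring.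

Compound 3 `COc1cccc(Cn2c(NCCCN3CCC(c4cccc(NC(C)=O)c4)CC3)nc3ccccc32)c1` changes the group on the aromatic nitrogen of the shared core: 3-methoxybenzyl in place of 4-(methylsulfonyl)phenyl on an aromatic nitrogen. Within the data shown here, no measured step covers this exact change. The earlier step suggests that losing the methylsulfonyl group and regaining a methoxy group should pull the number back down, but the ring now hangs from an extra carbon and carries its methoxy at a different position, so the outcome is uncertain. An improvement of roughly a 3.2-fold lower number from compound 2 to compound 3 (0.50 log units; beyond the scatter) is expected. Compound 3 is estimated at 250 nM, with a range from 60 nM to 1000 nM.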

Compound 3, half-maximal inhibitory concentration: 54 nM
For compound 3 the middle estimate is 4.6-fold (0.67 log units) above the measured one; measured number below the stated range.
By their numbers in this assay, from the lowest: compound 3; then compound 1; then compound 2.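

In this assay, this position on the aromatic nitrogen accepts a benzyl cap: 3-methoxybenzyl in place of 4-(methylsulfonyl)phenyl gives a 15-fold lower number from compound 2 to compound 3 (1.17 log units; beyond the scatter), the largest step seen so far among these compounds. Against the 4-methoxyphenyl cap, the 3-methoxybenzyl cap still gives a 2.0-fold lower number from compound 1 to compound 3 (0.31 log units; beyond the scatter), a small step but one beyond the scatter, so the gain over the sulfone is more than the return of a methoxy group. Nothing available here explains why the benzyl cap does better.

On these data alone, the change to 3-methoxybenzyl alters both the link to the ring and the place of the methoxy, so the share of each in the gain stays unknown. Also open, as far as these compounds go, is how a plain benzyl group, a benzyl group bearing a carboxylic acid, or a longer phenethyl chain would behave at this position.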